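This account rests on a few compounds, and the source may have more. Where it says the series, first, only, none or still open, it means among the compounds named here.

Measured so far in a functional assay on Huh-7 cells (Homo sapiens) for antiproliferative activity, read by CCK-8 assay, with a stated time of 72 h (on this read-out higher numbers stand for weaker inhibition of growth and lower numbers for stronger inhibition of growth), for two compounds:
- compound 1 `CC[C@@H]1C(=O)N(C)c2cnc(-n3ccc4cc(C(N)=O)ccc43)nc2N1C1CCCC1` gives 3090 nM
- compound 2 `CCCNC(=O)c1ccc2c(ccn2-c2ncc3c(n2)N(c2ccn(C)n2)C(CC)C(=O)N3C)c1` gives 7280 nM

Compound 1 has the lower of these two numbers, which marks stronger inhibition of growth, and its gap to compound 2 lies beyond the usual scatter. Compound 3 `CCCCNC(=O)c1ccc2c(ccn2-c2ncc3c(n2)N(C2CCCC2)[C@H](CC)C(=O)N3C)c1` differs from compound 1 by one change: butyl in place of hydrogen on an amide-type nitrogen. Among the measured compounds shown here, no measured pair shows this change alone, so no step beyond the scatter is expected in this assay in either direction. The estimated step is a 1.1-fold higher number from compound 1 to compound 3 (0.05 log units; within the scatter) and thus small. For compound 3 the estimated value is 3500 nM with an expected range from 900 nM to 11000 nM in this test.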

Compound 3, concentration for 50% growth inhibition: 683 nM
The estimate for compound 3 lay 5.1-fold (0.71 log units) above the measured number, outside the stated range (below it).
By their numbers in this assay, from the lowest: compound 3; then compound 1; then compound 2.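

In this assay butyl in place of hydrogen on an amide-type nitrogen gives a 4.5-fold lower number from compound 1 to compound 3 (0.66 log units; beyond the scatter) and so stronger inhibition of growth. Among the compounds shown here, this is the first measured pair to isolate this change, and it shows that the amide hydrogen is not required for this activity and that a butyl chain here is compatible with it. No measurement shown explains the gain.

From the compounds shown here alone, whether the gain depends on chain length remains open. A shorter methyl group, a longer hexyl chain, or a butyl chain ending in an amine or a carboxylic acid could test this.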